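The source may hold more compounds than are shown below. What is called first, only, known or untested is meant among the compounds shown, and "the series" means these compounds.

Measured in a functional assay on EL4 cells (Mus musculus) for inhibition, tested at 100 uM; on this read-out higher numbers stand for more inhibition at the one concentration tested (going by the name of the read-out) and lower numbers for less inhibition:
- compound 1 `CSc1[nH]ccc2ncnc1-2` gives < 5%, a limit of the assay rather than a number
- compound 2 `CN(C)c1nccc2c1ncn2C1O[C@H](CO)[C@@H](O)[C@H]1O` gives 10%
- compound 3 `[N-]=[N+]=Nc1nccc2c1ncn2[C@H]1C[C@H](O)[C@@H](CO)O1` gives 13%

Among the two numbers in this assay, compound 2 and compound 3 lie within the scatter of each other, so neither can be ranked over the other. Among the measured compounds shown here, the value of compound 1 sits at the limit (the limit of < 5% in this assay, at which 1 of the 3 values shown sits), and no step between the measured compounds is computed. Compound 4 `[N-]=[N+]=Nc1nccc2c1ncn2C1O[C@H](CO)[C@@H](O)[C@H]1O` is not yet measured; it differs from compound 2 in one place (azido in place of dimethylamino on an aromatic carbon). No step beyond the scatter is expected: the step from compound 2 to compound 4 in this assay is estimated at a number 2 percentage points higher from compound 2 to compound 4 (within the scatter), resting on compound 3 with 13%. Compound 4 is therefore estimated to give 12%, between 3% and 22%.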

Compound 4, a percentage reported as inhibition, at one concentration (the size of the read-out at that concentration, not a potency): < 5%
Compound 4: a limit, no number; the forecaster's own chance of this, stated with the estimate: 20%; at least 7 percentage points between middle value and limit.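

Swapping dimethylamino for azido on the aromatic carbon next to the ring nitrogen gives, in this assay, a number at least 5 percentage points lower from compound 2 to compound 4 (that floor lies within the scatter), so this first one-place change at the position does not raise the read-out. Compound 4 gives < 5%, which is a limit of the assay and not a number. The true size of the step therefore stays unknown, and compound 4 joins compound 1 at the floor: the limit of < 5% in this assay, at which 2 of the 4 values shown sit.

As far as these compounds go, whether a primary amine, a methoxy group or a longer alkyl chain on this carbon would read differently remains open. So does what number lies behind the limit of compound 4.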